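Chloro in place of trifluoromethyl: compound 1 to compound 3

The source may report more compounds than this note shows. Statements on the series, on what has been measured and on what is new or still open speak of the compounds shown alone.

Measured compounds:
compound 1 `CCCc1nc(-c2ccccc2)c(CNCCN2CCN(c3cccc(C(F)(F)F)c3)CC2)o1` — 1940 nM
compound 2 `CCCc1nc(-c2ccccc2)c(CNCCCN2CCN(c3ccccc3Cl)CC2)o1` — 2800 nM

In an assay on HEK293 cells for inhibition of Voltage-dependent T-type calcium channel subunit alpha-1G (Homo sapiens), read by patch clamp (on this read-out lower numbers stand for stronger inhibition and higher numbers for weaker inhibition), compound 1 gives 1940 nM, and compound 2 gives 2800 nM. These two numbers lie within the scatter of each other, so neither compound can be set apart from the other; compound 1 simply serves as the anchor for the step considered here.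

Compound 3 `CCCc1nc(-c2ccccc2)c(CNCCN2CCN(c3cccc(Cl)c3)CC2)o1` differs from compound 1 in one place: chloro in place of trifluoromethyl on an aromatic carbon. Among the measured compounds shown here, no measured pair shows this change, so no step size can be read from the data. The expectation is a small step from compound 1 to compound 3, most likely toward a somewhat higher number, and not clearly beyond the scatter. Compound 3 is therefore expected to give 2600 nM, with a range from 1000 nM to 6500 nM. The step this estimate means is a 1.3-fold higher number from compound 1 to compound 3 (0.13 log units; within the scatter), an expected step only.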

Compound 3, half-maximal inhibitory concentration: 1450 nM
For compound 3 the middle estimate is 1.8-fold (0.25 log units) above the measured one, within the range that was stated.
By their numbers in this assay, from the lowest: compounds 3, 1 and 2 (each within the scatter of the next).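

In this assay, among the compounds shown here, the exchange of trifluoromethyl for chloro on the aromatic carbon gives a 1.3-fold lower number from compound 1 to compound 3 (0.13 log units; within the scatter), the first step that can be read at this position. With 3-(trifluoromethyl)phenyl and 3-chlorophenyl, compound 1 and compound 3 cannot be set apart, so at this place four heavy atoms and one heavy atom are compatible with values inside the scatter of each other. Nothing available explains this result or bears on it.

Going by these compounds, whether the position accepts groups of another kind, such as an amine, a carboxylic acid or a methoxy group, remains open. Compound 2 differs from compound 1 and compound 3 in more than one place, so steps for the chain and for the placing of chloro cannot be read.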